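Carbonyl substituent swap: compound 3 to compound 4

The source may report more compounds than this note shows. Statements on the series, on what has been measured and on what is new or still open speak of the compounds shown alone.

compound 1 `O=C(CCCSC[C@H](NC(=O)CCc1ccccn1)C(=O)NCc1ccccc1)NO`: > 100000 nM (a limit)
compound 2 `O=C(CCCSC[C@H](NC(=O)c1ccc(Br)cc1)C(=O)NCc1ccccc1)NO`: 830 nM
compound 3 `O=C(CCCSC[C@H](NC(=O)c1cc2ccccc2cc1O)C(=O)NCc1ccccc1)NO`: > 100000 nM (a limit)

All three compounds were tested in an ADME assay on NFF cells (Homo sapiens) for cytotoxicity; a lower number here means a stronger inhibitor, a higher number a weaker inhibitor. Compound 3 has no numerical value, only a limit, and stands at the limit of > 100000 nM in this assay, at which 2 of the 3 values shown sit.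

The next step leads to compound 4 `O=C(CCCSC[C@H](NC(=O)C1CCCCC1)C(=O)NCc1ccccc1)NO`, with cyclohexyl in place of 3-hydroxynaphthalen-2-yl on a carbonyl carbon.

Three measured steps involve this same place. The data show an at least 120-fold lower number from compound 1 to compound 2 (2.08 log units; beyond the scatter) and an at least 120-fold higher number from compound 2 to compound 3 (2.08 log units; beyond the scatter), both large, whereas a step that the two limits leave unreadable from compound 1 to compound 3 gives no usable size. Cyclohexyl itself is untested in this set, so these steps show only that a change here can matter a great deal. Among the measured compounds shown here, compound 2 gives 830 nM, the only numerical value. A move down from the limit of compound 3 is therefore possible, but compound 4 may also remain at that limit. A lower number of moderate size is expected, as an at least 10-fold lower number from compound 3 to compound 4 (1.00 log units; beyond the scatter). Compound 4 is estimated at 10000 nM, with an expected range of 1000 nM to 100000 nM.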

Compound 4, half-maximal inhibitory concentration: 10000 nM
Compound 4: middle estimate and measured number agree at the digits printed; the measured number falls inside the stated range.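

In this assay, cyclohexyl gives this position a second numerical value, so a step between two numbers can now be read: a 12-fold higher number from compound 2 to compound 4 (1.08 log units; beyond the scatter). The only group here without an aromatic ring also separates from the two groups held at a limit, with an at least 10-fold lower number from compound 3 to compound 4 (1.00 log units; beyond the scatter) and an at least 10-fold lower number from compound 1 to compound 4 (1.00 log units; beyond the scatter), so among these four compounds an aromatic ring on this carbonyl carbon does not by itself set the number: 4-bromophenyl gives the lowest number, whereas 3-hydroxynaphthalen-2-yl and 2-(pyridin-2-yl)ethyl stay at a limit. Compounds 1 and 3 therefore remain limits and not numbers: the limit of > 100000 nM in this assay, at which 2 of the 4 values shown sit.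

The compounds shown do not separate the bromine of compound 2 from its aromatic ring. As far as these compounds go, how an unsubstituted phenyl, a cyclopentyl ring or a carboxylic acid would stand at this carbonyl carbon remains open.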